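The compounds below may be only part of what the source reports. "The series", "measured", "known", "first", "only" and "open" are said of these compounds alone.

Working notes on the series, read in an ADME assay on the whole organism (Mus musculus, strain CD1) for metabolic stability, at a dose of 2 mg/kg by the intravenous route; on this read-out lower numbers stand for a shorter-lived compound and higher numbers for a longer-lived compound. Compound 1 (`COc1cc(N2C(=O)C3(CCC3)N(c3ccc(OC4CCN(C)CC4)nc3)C2=S)cnc1C#N`) gives 4.2 h, compound 2 (`CN1CCC(Oc2ccc(N3C(=S)N(c4cnc(C#N)c(C(F)(F)F)c4)C(=O)C34CCC4)cn2)CC1`) gives 12.5 h, and compound 3 (`Cc1cc(N2C(=O)C3(CCC3)N(c3ccc(OC4CCNCC4)nc3)C2=S)cnc1C#N`) gives 3 h. The values of compound 3 and compound 1 lie within the scatter of each other, while the value of compound 2 stands clearly higher than both.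

Compound 4 (`N#Cc1ncc(N2C(=O)C3(CCC3)N(c3ccc(OC4CCNCC4)nc3)C2=S)cc1C(F)(F)F`) differs from compound 3 in one place: trifluoromethyl in place of methyl on an aromatic carbon. In words, this is trifluoromethyl in place of methyl on an aromatic carbon.

Among the compounds with values here, one measured step bears on this change: a 3.0-fold higher number from compound 1 to compound 2 (0.47 log units; beyond the scatter). It also brings in trifluoromethyl on an aromatic carbon, but there the group leaving is methoxy, not methyl. Within the data shown here, that pair also differs from compound 3 elsewhere in the structure, and no measured pair shows methyl giving way to trifluoromethyl. The evidence is therefore a single indirect step, modest in size and beyond the scatter. A modest rise in this assay is expected, slightly smaller than that step and with wide uncertainty.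

The estimated change is a 2.7-fold higher number from compound 3 to compound 4 (0.43 log units; beyond the scatter). For compound 4 the expected value is 8 h, with an estimated range of 4 h to 16 h.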

Compound 4, half-life: 5.99 h
The estimate for compound 4 lay 1.3-fold (0.13 log units) above the measured number; the range from low to high includes it.
By their numbers in this assay, from the lowest: compounds 3, 1 and 4 (each within the scatter of the next); then compound 2.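

In this assay, trifluoromethyl in place of methyl on the aromatic carbon ortho to a cyano group gives a 2.0-fold higher number from compound 3 to compound 4 (0.30 log units; within the scatter) and so cannot be told from the scatter, whereas the step with methoxy leaving, read on compounds with methyl on the amine nitrogen in the ring, gives a 3.0-fold higher number from compound 1 to compound 2 (0.47 log units; beyond the scatter) and lies beyond it. The amine nitrogen now has a one-place comparison of its own: with trifluoromethyl held fixed on the aromatic carbon, hydrogen in place of methyl gives a 2.1-fold lower number from compound 2 to compound 4 (0.32 log units; beyond the scatter) and lies beyond the scatter. A change at that nitrogen alone is therefore enough to move this read-out, although this rests on a single pair.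

On these data alone, whether the amine step has a similar size with methyl on the aromatic carbon remains open, as does the effect of methoxy there when the amine nitrogen carries hydrogen. Also open, as far as these compounds go, is how a chlorine atom or an ethyl group on the same aromatic carbon, or an ethyl group on the amine nitrogen, would read against these compounds. No measurement available here explains any of these differences.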